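This account rests on a few compounds, and the source may have more. Where it says the series, first, only, none or still open, it means among the compounds named here.

Measured compounds in a functional assay on CHO cells for antagonist activity at Orexin receptor type 2 (Homo sapiens), read by FLIPR and calcium flux; a higher number here means a weaker inhibitor, a lower number a stronger inhibitor:
compound 1 `CCc1nc(Cl)c2n1CCN([C@@H](C(=O)NC)c1ccccc1)[C@H]2CCc1ccc(F)c(F)c1F` gives 5 nM
compound 2 `CCc1nc(Cl)c2n1CCN([C@@H](C(=O)NC)c1ccccc1)[C@H]2CCc1cccc(C(F)(F)F)c1F` gives 9 nM
compound 3 `CNC(=O)[C@@H](c1ccccc1)N1CCn2c(C3CC3)nc(Cl)c2[C@@H]1CCc1ccc(C(F)(F)F)cc1` gives 9 nM

Compound 3 stands level with compound 2 at the digits shown, and these two carry the highest numbers of the three. Among the compounds with values here, compound 1 gives 5 nM and compound 3 gives 9 nM; no single-point step connects them, and the two values lie within the scatter of each other, so no order among the three can be read from these numbers.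

Compound 4 `CNC(=O)[C@@H](c1ccccc1)N1CCn2c(C3CC3)nc(Cl)c2[C@@H]1CCc1ccc(C(F)(F)F)c(F)c1` differs from compound 3 by fluoro in place of hydrogen on an aromatic carbon. Within the data shown here, the only measured step that touches the same part of the molecule is a 1.8-fold higher number from compound 1 to compound 2 (0.26 log units; within the scatter), a rearrangement of fluorine substitution on the aryl ring at the end of the two-carbon chain, and it stayed within the scatter. On that basis the added fluorine in compound 4 is expected to move the number little, if at all: no change at the digits printed from compound 3 to compound 4 (within the scatter). Compound 4 is therefore estimated at 9 nM in this assay, with a range of 4 nM to 20 nM.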

Compound 4, half-maximal inhibitory concentration: 10 nM
Compound 4: the middle estimate sits 1.1-fold (0.05 log units) below what was measured; the range from low to high includes it.
By their numbers in this assay, from the lowest: compounds 1, 2, 3 and 4 (each within the scatter of the next).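

In this assay fluoro in place of hydrogen on the aromatic carbon ortho to the trifluoromethyl group gives a 1.1-fold higher number from compound 3 to compound 4 (0.05 log units; within the scatter) and so leaves 4-(trifluoromethyl)phenyl and 3-fluoro-4-(trifluoromethyl)phenyl indistinguishable in this series. Unlike the earlier step between two differently fluorinated aryl groups, this one adds a single fluoro to a ring that keeps its trifluoromethyl group, with the rest of the molecule unchanged, so this aromatic carbon accepts that one atom without a readable shift. No measurement shown here offers an explanation for this result.

Open, on these data alone, is whether a methoxy group, a nitrile or an amine on this same aromatic carbon would also stay within the scatter of compound 3. Also open, as far as these compounds go, is whether the fluoro step reads the same with ethyl in place of cyclopropyl on the core.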